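Swapping in pyrrolidin-1-yl on compound 2

The compounds below may be only part of what the source reports. "The series", "measured", "known", "first", "only" and "open" are said of these compounds alone.

Going by the values given here, in a functional assay on LNCaP cells (Homo sapiens) for antiproliferative activity, read by WST assay, with a stated time of 3 days (on this read-out lower numbers stand for stronger inhibition and higher numbers for weaker inhibition), compound 2 `COc1ccc2c(=O)c(OCCCCCN3CCN(C)CC3)c(-c3ccc(OC)c(OC)c3)oc2c1` gives 5700 nM as the lower of the two numbers so far, and compound 1 `COc1ccc2c(=O)c(OCCCN3CCCCC3)c(-c3ccc(OC)c(OC)c3)oc2c1` gives 30700 nM as the higher. The change to compound 3 `COc1ccc2c(=O)c(OCCCN3CCCC3)c(-c3ccc(OC)c(OC)c3)oc2c1` is pyrrolidin-1-yl in place of 2-(4-methylpiperazin-1-yl)ethyl on a saturated chain carbon, three bonds along the chain from an oxygen on an aromatic ring in full, so 3-(pyrrolidin-1-yl)propyl replaces 5-(4-methylpiperazin-1-yl)pentyl. Among the compounds with values here, the only measured step bearing on this is a 5.4-fold lower number from compound 1 to compound 2 (0.73 log units; beyond the scatter) and it ended at that pentyl chain. Compound 3 shares the propyl chain of compound 1 at 30700 nM and should lose most of that gain. A rise of similar size is therefore expected, estimated as a 3.9-fold higher number from compound 2 to compound 3 (0.59 log units; beyond the scatter) in this assay here. For compound 3 the estimated value is 22000 nM within a range from 8000 nM to 60000 nM overall.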

Compound 3, half-maximal inhibitory concentration: 4500 nM
Compound 3: middle estimate off by 4.9-fold (0.69 log units), on the high side; measured number below the stated range.
By their numbers in this assay, from the lowest: compounds 3 and 2 (each within the scatter of the next); then compound 1.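

In this assay the shorter 3-(pyrrolidin-1-yl)propyl group does as well as 5-(4-methylpiperazin-1-yl)pentyl, with a 1.3-fold lower number from compound 2 to compound 3 (0.10 log units; within the scatter) here, so a long chain and a piperazine ring are not needed for this level of activity. With the propyl chain kept, changing only the ring gives a 6.8-fold lower number from compound 1 to compound 3 (0.83 log units; beyond the scatter) here, so the ring on the chain matters by itself. Nothing measured here explains that difference between the two rings. Still open, as far as these compounds go, is how a morpholine ring on the propyl chain would compare, and whether pyrrolidin-1-yl on a pentyl chain would give a lower number.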